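This account rests on a few compounds, and the source may have more. Where it says the series, first, only, none or still open, it means among the compounds named here.

Of the compounds shown here, three that share one core have been measured in a functional assay on HCT-116 cells (Homo sapiens) for inhibition, read by sulforhodamine B assay, with a stated time of 48 h, tested at 10 uM; a higher number here means a weaker effect of the compound at the concentration tested, a lower number a stronger effect. Compound 1 `COc1cc(Cl)cc(-c2nn(-c3cccc(NC(=O)c4ccc(Cl)c(Cl)c4)c3)cc2-c2ccncc2)c1` gives 44.1%. Compound 2 `COc1cc(Cl)cc(-c2nn(-c3cccc(NC(=O)Nc4ccc(Cl)c(C(F)(F)F)c4)c3)cc2-c2ccncc2)c1` gives 3.39%, and compound 3 `COc1cc(Cl)cc(-c2nn(-c3cccc(NC(=O)Nc4cccc(C(F)(F)F)c4)c3)cc2-c2ccncc2)c1` gives 5.07%, so compound 3 stands second highest of the three, close to compound 2 and far from compound 1. The steps of a number 40.7 percentage points lower from compound 1 to compound 2 (beyond the scatter) and a number 39 percentage points lower from compound 1 to compound 3 (beyond the scatter) were large drops, while the step of a number 1.7 percentage points higher from compound 2 to compound 3 (within the scatter) stayed within the scatter. Compound 4 `COc1cc(Cl)cc(-c2nn(-c3cccc(NC(=O)c4cccc(C(F)(F)F)c4)c3)cc2-c2ccncc2)c1` differs from compound 3 in one place: 3-(trifluoromethyl)phenyl in place of (3-(trifluoromethyl)phenyl)amino on a carbonyl carbon. A large rise in this assay is expected because a number 39 percentage points lower from compound 1 to compound 3 (beyond the scatter) went the other way for the opposite change. Compound 4 is therefore estimated at 40%, between 15% and 70%. The expected step is a number 34.9 percentage points higher from compound 3 to compound 4 (beyond the scatter).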

Compound 4, a percentage reported as activity, at one concentration (the size of the read-out at that concentration, not a potency): 34.1%
Compound 4: the middle estimate sits 5.9 percentage points above what was measured; measured number inside the range.
By their numbers in this assay, from the lowest: compounds 2 and 3 (each within the scatter of the next); then compounds 4 and 1 (each within the scatter of the next).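

In this assay, the step of a number 29 percentage points higher from compound 3 to compound 4 (beyond the scatter) shows that the aryl group alone does not give the strong effect: with 3-(trifluoromethyl)phenyl bonded directly to the carbonyl carbon, the amino nitrogen and its hydrogen-bond donor are gone, and the effect weakens. The step of a number 30.7 percentage points higher from compound 2 to compound 4 (beyond the scatter) is a comparable gap, while a number 10 percentage points lower from compound 1 to compound 4 (within the scatter) separates the two aryl groups on that carbon by no more than the scatter. Nothing measured here explains why that nitrogen matters. From the compounds shown here alone, it remains open whether phenoxy, with oxygen in that nitrogen's place, or a small methylamino group would keep the strong effect.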